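The compounds below may be only part of what the source reports. "The series", "measured", "known", "first", "only" and "open" are said of these compounds alone.

Measured compounds in an assay on membranes from brain for binding affinity to neutral cholesterol ester hydrolase 1 (Mus musculus), read by fluorescence, with stated times of 1 h and 30 min; on this read-out higher numbers stand for weaker inhibition and lower numbers for stronger inhibition:
compound 1 `Cc1cnn(C(=O)NCc2ccc(OCc3ccccc3)cc2)c1` — > 100000 nM
compound 2 `N#Cc1cnn(C(=O)NCc2ccc(OCc3ccccc3)cc2)c1` — > 100000 nM
compound 3 `Cc1cnn(C(=O)N2CCCN(Cc3ccc(OCc4ccccc4)cc3)CC2)c1` — > 100000 nM

All three values are limits of this assay, not numbers. Compound 1 gives only the limit > 100000 nM. Compound 2 gives only the limit > 100000 nM. Compound 3 stands only at the limit > 100000 nM; no number is known for it. Compound 4 `N#Cc1cnn(C(=O)N2CCCN(Cc3ccc(OCc4ccccc4)cc3)CC2)c1` differs from compound 3 by cyano in place of methyl on an aromatic carbon. For the measured compounds named here, the one measured step that bears on this change, a step that the two limits leave unreadable from compound 1 to compound 2, has no readable size; both of its ends sit at the limit of > 100000 nM in this assay, at which 3 of the 3 values shown sit. The step that the limit leaves unreadable from compound 3 to compound 4 is therefore expected to stay within the scatter, with compound 4 most likely remaining at the limit. The estimate for compound 4 in this assay is 150000 nM, range 50000 nM to 500000 nM.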

Compound 4, half-maximal inhibitory concentration: > 100000 nM
Compound 4 gave a limit, no number (the forecaster's own chance of this, stated with the estimate: 90%); the middle value does not contradict the limit.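

The step from compound 3 to compound 4 cannot be read: both ends are limits, not numbers. The compounds shown leave open how cyano in place of methyl affects inhibition at any readable value.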